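From Nitro to Methoxy: Expecting the Value of Compound 4

The compounds below may be only part of what the source reports. "The series", "measured", "known", "first", "only" and "open" are said of these compounds alone.

Three compounds share one core and differ only in a single group on one aromatic ring. Compound 1 `COc1ccc(CN(C(=O)CSc2nc3ccccc3s2)c2cc(OC)c(OC)c(OC)c2)cc1C(F)(F)F` carries a trifluoromethyl there; in a functional assay on PC-3 cells (Homo sapiens) for antiproliferative activity, read by MTT assay, with a stated time of 48 h (on this read-out higher numbers stand for weaker inhibition and lower numbers for stronger inhibition), compound 1 reaches only the assay limit of > 80000 nM, so it is not a number. Compound 2 `COc1ccc(CN(C(=O)CSc2nc3ccccc3s2)c2cc(OC)c(OC)c(OC)c2)cc1N=[N+]=[N-]` carries an azido and gives 14400 nM. Compound 3 `COc1ccc(CN(C(=O)CSc2nc3ccccc3s2)c2cc(OC)c(OC)c(OC)c2)cc1[N+](=O)[O-]` carries a nitro and gives 26500 nM, the higher of the two numbers recorded, though the step of a 1.8-fold higher number from compound 2 to compound 3 (0.26 log units; within the scatter) lies within the scatter.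

Compound 4 `COc1ccc(CN(C(=O)CSc2nc3ccccc3s2)c2cc(OC)c(OC)c(OC)c2)cc1OC` is the next step: methoxy in place of nitro on an aromatic carbon. For the measured compounds named here, no measured pair covers a methoxy at this place. The steps that come closest are an at least 3.0-fold lower number from compound 1 to compound 3 (0.47 log units; beyond the scatter), which only shows that a nitro moves below a limit, and a 1.8-fold higher number from compound 2 to compound 3 (0.26 log units; within the scatter), which shows nitro and azido giving much the same reading. Both point to a compound whose number is likely to stay in the same weak region, with no firm direction for the methoxy.

For compound 4 the expected step is a 1.1-fold higher number from compound 3 to compound 4 (0.05 log units; within the scatter), roughly no change beyond the scatter. The estimate for compound 4 is therefore 30000 nM, within a range from 9000 nM to 90000 nM.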

Compound 4, half-maximal inhibitory concentration: > 80000 nM
Compound 4 gave a limit, no number; the forecaster's own chance of this, stated with the estimate: 30%; middle value at least 2.6-fold (0.42 log units) away from the limit.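

Placing methoxy here shows that this position does not tolerate every small group in this assay: replacing nitro gives an at least 3.0-fold higher number from compound 3 to compound 4 (0.47 log units; beyond the scatter), and replacing azido gives an at least 5.5-fold higher number from compound 2 to compound 4 (0.74 log units; beyond the scatter). Among the four groups shown, the two that contain nitrogen, nitro and azido, give readable numbers, while the 3,4-dimethoxyphenyl of compound 4 and the trifluoromethyl-bearing ring of compound 1 do not, so a group's small size alone does not secure a number here, since methoxy brings fewer heavy atoms than nitro. The step between compound 1 and compound 4 cannot be read, because both stop at the same limit rather than at a number: the limit of > 80000 nM in this assay, at which 2 of the 4 values shown sit.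

From the compounds shown here alone, how far compound 1 and compound 4 lie past that limit remains unknown, so these compounds cannot show whether methoxy and trifluoromethyl differ at all. Going by these compounds, it also remains open whether a readable number at this place depends on nitrogen in the group, a question that an amine or a nitrile here would help to settle, while a hydroxyl would show how a second oxygen-bearing group behaves.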